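A few compounds are considered here, and "the series" means these few. Any claim that something is new, unique, unknown or untested is made for them only; others in the source may bear on it.

Measured compounds:
compound 1, `Cc1nn(-c2ncnc3nc[nH]c23)c2c1C(OCC(=O)c1ccc(F)cc1)CC(=O)N2`, 3 nM
compound 2, `Cc1noc(C)c1COC1CC(=O)Nc2c1c(C)nn2-c1ncnc2nc[nH]c12`, 5 nM
compound 3, `Cc1nn(-c2ncnc3nc[nH]c23)c2c1C(OCc1ccccc1Cl)CC(=O)N2`, 2 nM

In a functional assay on HEK293 cells for agonist activity at G-protein coupled receptor 39 (Homo sapiens), read by scintillation proximity assay and inositol phosphate accumulation, with a stated time of 75 min, in the presence of a further agent that is not named here (a higher number here means that more compound is needed for the effect, a lower number that less compound is needed), compound 3 gives the lowest of the three numbers. Its nearest neighbour is compound 1, a 1.5-fold lower number from compound 1 to compound 3 (0.18 log units; within the scatter); the furthest is compound 2, a 2.5-fold lower number from compound 2 to compound 3 (0.40 log units; beyond the scatter). Compound 1 and compound 2 lie within the scatter of each other, a 1.7-fold higher number from compound 1 to compound 2 (0.22 log units; within the scatter).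

Compound 4, `Cc1nn(-c2ncnc3nc[nH]c23)c2c1C(OCCn1nccc1C)CC(=O)N2`, differs from compound 3 in one place: (5-methyl-1H-pyrazol-1-yl)methyl in place of 2-chlorophenyl on a saturated chain carbon bound to an oxygen on a saturated carbon. Going by the values given here, the steps that bear on this change are the three at the same saturated chain carbon. Two of them stay within the scatter, and the one that goes beyond it is the modest move from the five-membered heteroaromatic group of compound 2 to the 2-chlorophenyl of compound 3. Since compound 4 again carries a five-membered aromatic ring with two hetero atoms in that place, the number in this assay is expected to rise modestly, much as compound 2 sits above compound 3, with a 2.0-fold higher number from compound 3 to compound 4 (0.30 log units; within the scatter). Compound 4 is therefore estimated at 4 nM, in the range 1.5 nM to 12 nM.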

Compound 4, half-maximal effective concentration: 10 nM
Estimate against measurement, compound 4: 2.5-fold (0.40 log units) below; the measured number falls inside the stated range.
By their numbers in this assay, from the lowest: compounds 3, 1, 2 and 4 (each within the scatter of the next, the first and the last beyond it).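

In this assay, going by these compounds alone, the (5-methyl-1H-pyrazol-1-yl)methyl group is the first at this saturated chain carbon to lie beyond the scatter of two other groups, with a 5.0-fold higher number from compound 3 to compound 4 (0.70 log units; beyond the scatter) and a 3.3-fold higher number from compound 1 to compound 4 (0.52 log units; beyond the scatter), while it stays close to the 3,5-dimethyl-1,2-oxazol-4-yl group, with a 2.0-fold higher number from compound 2 to compound 4 (0.30 log units; within the scatter). Both groups with a five-membered aromatic ring with 2 hetero atoms now stand beyond the scatter above the 2-chlorophenyl group of compound 3, although compound 1, which has no such ring, lies within the scatter of compound 2, so ring type alone does not sort these compounds. Nothing measured here accounts for these steps.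

The compounds shown leave open how an amine, a carboxylic acid or a longer chain would read on this saturated chain carbon. They also leave open whether a 3-chlorophenyl or 4-chlorophenyl group would match the 2-chlorophenyl group.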